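A few compounds are considered here, and "the series" means these few. Any claim that something is new, unique, unknown or untested is made for them only; others in the source may bear on it.

Measured so far in a functional assay on NCI-H460 cells (Homo sapiens) for antiproliferative activity, read by MTT assay, with a stated time of 48 h; a higher number here means a weaker inhibitor, a lower number a stronger inhibitor:
Compound 1, `CC1(C)Cc2c(ccc(C(=O)/C=C/c3cn(-c4ccccc4)nc3-c3cccc([N+](=O)[O-])c3)c2OCc2ccccc2)O1`, gives > 100000 nM, a limit of the assay.
Compound 2, `CC1(C)Cc2c(OCc3ccccc3)ccc(C(=O)/C=C/c3cn(-c4ccccc4)nc3-c3cccc([N+](=O)[O-])c3)c2O1`, gives > 100000 nM, a limit of the assay.
Compound 3, `CC1(C)Cc2c(ccc(C(=O)/C=C/c3ccccc3)c2OCc2ccccc2)O1`, gives > 100000 nM, a limit of the assay.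

Compound 3 therefore stands at the limit of > 100000 nM in this assay, at which 3 of the 3 values shown sit, with no numbered value of its own, and every value shown for the series is such a limit. Among the compounds with values here, no step between two measured compounds is available, so the series gives no measured direction for any change.

Compound 4, `CC1(C)Cc2c(ccc(C(=O)/C=C/c3ccc(Cl)cc3)c2OCc2ccccc2)O1`, differs from compound 3 by chloro in place of hydrogen on an aromatic carbon.

With every measured value sitting at the limit of > 100000 nM in this assay, at which 3 of the 3 values shown sit, the step expected from this change in this assay is none beyond the scatter, as a number no higher from compound 3 to compound 4 (the limit leaves the size open). Compound 4 is accordingly expected to give about 100000 nM, within 30000 nM to 300000 nM, most probably reported once more only as a limit.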

Compound 4, half-maximal inhibitory concentration: > 100000 nM
Compound 4: only a limit was reported; the forecaster's own chance of this, stated with the estimate: 80%; the middle value lies on the limit itself.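

Compound 3 and compound 4 both stand only at a limit, so no step can be read for chloro in place of hydrogen: the limit of > 100000 nM in this assay, at which 4 of the 4 values shown sit.

The compounds shown leave open what any change on the shared core does to a numbered value in this assay.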